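Extending the Methyl Ester of Compound 2

The source may report more compounds than this note shows. Statements on the series, on what has been measured and on what is new or still open speak of the compounds shown alone.

Compound 2 `C/C=C1/[C@H](O[C@@H]2O[C@H](CO)[C@@H](O)[C@H](O)[C@H]2O)OC=C(C(=O)OC)[C@H]1CC(=O)OC`: > 80000 nM
Compound 1 `C/C=C1/[C@H](O[C@@H]2O[C@H](CO)[C@@H](O)[C@H](O)[C@H]2O)OC=C(C(=O)OC)[C@H]1CC(=O)OC[C@H]1O[C@@H](Oc2ccc(/C=C/CO)cc2OC)[C@H](O)[C@@H](O)[C@@H]1O`: > 80000 nM

In a functional assay on RAW264.7 cells (Mus musculus) for inhibition, read by Griess assay, with a stated time of 24 h (a higher number here means a weaker inhibitor, a lower number a stronger inhibitor), compound 2 gives only a limit, > 80000 nM, not a number. Compound 1 likewise gives only a limit in this assay, > 80000 nM. Both values therefore sit at the limit of > 80000 nM in this assay, at which 2 of the 2 values shown sit, so compound 2 stands at the edge of what this assay can report.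

Compound 3 `C/C=C1/[C@H](O[C@@H]2O[C@H](CO)[C@@H](O)[C@H](O)[C@H]2O)OC=C(C(=O)OC)[C@H]1CC(=O)OCCc1ccc(O)c(O)c1` has not yet been measured. It differs from compound 2 in one place: 3,4-dihydroxybenzyl in place of hydrogen on a saturated chain carbon bound to an oxygen next to a carbonyl group. Within the data shown here, no step between measured compounds exists here, so only an expectation can be offered: a moderate step toward stronger inhibition, an at least 1.6-fold lower number from compound 2 to compound 3 (0.20 log units; that floor lies within the scatter), is expected. Compound 3 is estimated at 50000 nM, within 15000 nM to 200000 nM.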

Compound 3, half-maximal inhibitory concentration: > 80000 nM
Compound 3: only a limit was reported (the forecaster's own chance of this, stated with the estimate: 50%); at least 1.6-fold (0.20 log units) between middle value and limit.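

The step between compound 2 and compound 3 cannot be read, since both give only a limit in this assay: the limit of > 80000 nM in this assay, at which 3 of the 3 values shown sit. The compounds shown leave open whether any change at this ester gives a number rather than a limit.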